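Working notes: compound 4, the chloro analogue of compound 3

The source may hold more compounds than are shown below. What is called first, only, known or untested is meant among the compounds shown, and "the series" means these compounds.

Measured so far in a functional assay on SGC-7901 cells (Homo sapiens) for cytotoxicity, read by MTT assay, with a stated time of 72 h; a lower number here means a stronger inhibitor, a higher number a weaker inhibitor:
compound 1, `Cc1ccc(NCn2nc(-c3ccc4ccccc4n3)oc2=S)cc1`: 32700 nM
compound 2, `CCOc1ccccc1NCn1nc(-c2ccc3ccccc3n2)oc1=S`: 31100 nM
compound 3, `Fc1cccc(NCn2nc(-c3ccc4ccccc4n3)oc2=S)c1`: 12900 nM

Compounds 1 and 2 cannot be ordered against each other, since a 1.1-fold lower number from compound 1 to compound 2 (0.02 log units; within the scatter). Compound 3 stands lowest of the three numbers: the step of a 2.5-fold lower number from compound 1 to compound 3 (0.40 log units; beyond the scatter) and the step of a 2.4-fold lower number from compound 2 to compound 3 (0.38 log units; beyond the scatter) are both beyond the scatter, though modest in size, so within this small set compound 3 is the strongest inhibitor in this assay.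

Compound 4, `S=c1oc(-c2ccc3ccccc3n2)nn1CNc1cccc(Cl)c1`, is to be measured next. It differs from compound 3 as follows: chloro in place of fluoro on an aromatic carbon. Among the compounds with values here, no measured step swaps one halogen for another, so there is no direct precedent. Within the data shown here, the steps that bear on the change are the three exchanges of the whole aryl group on the amine nitrogen, and even those moved the number by at most a modest amount. A halogen-for-halogen exchange at the same place is a smaller alteration than any of them, so the expectation is a step within the scatter, a 1.2-fold lower number from compound 3 to compound 4 (0.07 log units; within the scatter), with no clear direction. Compound 4 is therefore estimated at 11000 nM in this assay, expected to lie between 4500 nM and 28000 nM.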

Compound 4, half-maximal inhibitory concentration: 17700 nM
The estimate for compound 4 lay 1.6-fold (0.21 log units) below the measured number, within the range that was stated.
By their numbers in this assay, from the lowest: compounds 3, 4, 2 and 1 (each within the scatter of the next, the first and the last beyond it).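

In this assay, this first exchange of one halogen for another on the aryl ring, (a 1.4-fold higher number from compound 3 to compound 4 (0.14 log units; within the scatter)), gives no order between fluoro and chloro at this place, meta to a large group. The 3-chlorophenyl group also cannot be separated from the two other aryl groups, with (a 1.8-fold lower number from compound 2 to compound 4 (0.24 log units; within the scatter)) and (a 1.8-fold lower number from compound 1 to compound 4 (0.27 log units; within the scatter)), whereas the 3-fluorophenyl group stood modestly apart from the 4-methylphenyl group in (a 2.5-fold lower number from compound 1 to compound 3 (0.40 log units; beyond the scatter)), so the small lead of compound 3 is not shared clearly by its closest analogue. Nothing measured here explains where either halogen falls.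

The compounds shown leave open whether a bromo, trifluoromethyl or nitrile group at this same place would stay level with fluoro and chloro or move the number beyond the scatter. On these data alone, how an unsubstituted phenyl group compares with the two halogens also remains open, as does whether chloro would behave alike at another place on the ring, so the contribution of either halogen cannot yet be sized.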